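Trimming a dibromoethenyl chain in a cytotoxic dihydropyran series

The source may hold more compounds than are shown below. What is called first, only, known or untested is meant among the compounds shown, and "the series" means these compounds.

In a functional assay on A2780 cells (Homo sapiens) for antiproliferative activity (a higher number here means that more compound is tolerated, a lower number that less compound is tolerated), compound 1 `C[C@H]1CC(Cl)=C([Si](C)(C)C)[C@@H](C2CCCCC2)O1` gives 61000 nM, compound 2 `C[Si](C)(C)C1=C(Cl)C[C@H](C2CCCCC2)O[C@@H]1C1CCCCC1` gives 90000 nM, and compound 3 `C[C@@H]1O[C@H](CCC=C(Br)Br)C([Si](C)(C)C)=C(Cl)[C@H]1C` gives 70000 nM. Compound 3 lies within the scatter of both compound 1 and compound 2, so the three stand together. Among the measured compounds shown here, the only single-point step measured, a 1.5-fold higher number from compound 1 to compound 2 (0.17 log units; within the scatter), is also within the scatter. Compound 4 `C=CCC[C@H]1O[C@@H](C)[C@H](C)C(Cl)=C1[Si](C)(C)C` differs from compound 3 by vinyl in place of 2,2-dibromoethenyl on a saturated chain carbon, two bonds along the chain from a saturated ring carbon. For the measured compounds named here, no measured step touches this chain, and the one step known shows no movement, so compound 4 is expected to stay in the same region of this assay, with a step of a 1.1-fold higher number from compound 3 to compound 4 (0.03 log units; within the scatter) that is not expected to exceed the scatter. Compound 4 is therefore estimated at 75000 nM, likely between 30000 nM and 160000 nM.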

Compound 4, concentration lethal to 50% of the cells: 19000 nM
Compound 4: the middle estimate sits 3.9-fold (0.60 log units) above what was measured; measured number below the stated range.
By their numbers in this assay, from the lowest: compound 4; then compounds 1, 3 and 2 (each within the scatter of the next).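

In this assay, vinyl in place of 2,2-dibromoethenyl on a saturated chain carbon, two bonds along the chain from a saturated ring carbon, gives a 3.7-fold lower number from compound 3 to compound 4 (0.57 log units; beyond the scatter). Among the compounds shown here, this modest step is the first in the set to go beyond the scatter, so less compound is tolerated once the two bromine atoms are gone. Nothing available explains the shift. The compounds shown leave open whether 2,2-dichloroethenyl, 2-bromoethenyl or ethyl on that same carbon would behave like vinyl or like 2,2-dibromoethenyl.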